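Swapping Methylsulfonyl for Allyl on a Weak Inhibitor

The compounds below may be only part of what the source reports. "The series", "measured", "known", "first", "only" and "open" are said of these compounds alone.

Three compounds have been measured in a functional assay for inhibition, with Homo sapiens as the target; on this read-out higher numbers stand for weaker inhibition and lower numbers for stronger inhibition:

compound 1 `O=C(O)COc1cccc(/C=C\c2nc(-c3ccccc3)c(-c3ccccc3)o2)c1` gives 180 nM
compound 2 `CCOC(=O)/C(=C\c1cccc(OCC(=O)O)c1OC)c1nc(-c2ccccc2)c(-c2ccccc2)o1` gives 130 nM
compound 3 `CS(=O)(=O)C(Cc1cccc(OCC(=O)O)c1)c1nc(-c2ccccc2)c(-c2ccccc2)o1` gives 7960 nM

All three share the same core, differing in what sits on the chain that links it to the aromatic ring carrying the oxyacetic acid. Compound 3 has the highest number of the three in this assay, and both other compounds give far lower numbers, well beyond the scatter of repeated measurements, so compound 3 is the weakest inhibitor of this small set.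

Compound 4 `C=CCC(Cc1cccc(OCC(=O)O)c1)c1nc(-c2ccccc2)c(-c2ccccc2)o1` is the next step from compound 3. The change is allyl in place of methylsulfonyl on a saturated chain carbon bound to an aromatic carbon and a saturated chain carbon. Among the measured compounds shown here, no pair of measured compounds shows this exact exchange, so its effect can only be guessed from the values at hand. Compound 1, with 180 nM, and compound 2, with 130 nM, both lack a methylsulfonyl and give much lower numbers than compound 3, which suggests that the allyl-bearing compound 4 is expected to move toward them. The step from compound 3 to compound 4 in this assay is expected to be an 8.8-fold lower number from compound 3 to compound 4 (0.95 log units; beyond the scatter), a clear fall in the number. For compound 4 the estimate is 900 nM, with a range from 150 nM to 5000 nM.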

Compound 4, half-maximal inhibitory concentration: 570 nM
Compound 4: the middle estimate sits 1.6-fold (0.20 log units) above what was measured, within the range that was stated.
By their numbers in this assay, from the lowest: compounds 2 and 1 (each within the scatter of the next); then compound 4; then compound 3.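

In this assay, among the compounds shown here, the exchange of methylsulfonyl for allyl on this saturated chain carbon gives a 14-fold lower number from compound 3 to compound 4 (1.15 log units; beyond the scatter), a large step and the first one here in which only this group changes, so it shows directly that the group at this place strongly affects the read-out. The earlier compounds shown here could not show this, as they differ from one another in more than one place. The swap itself changes several things at once, from 4 heavy atoms and 2 hydrogen-bond acceptors in methylsulfonyl to 3 heavy atoms and 0 hydrogen-bond acceptors in allyl, and no measurement available here says which of these differences, if any, accounts for the lower number.

Still open, on these data alone, is whether the double bond of allyl matters, which a saturated propyl group at this place would help to answer. It is also unclear whether a hydroxyl group or an amine there would give a number closer to that of compound 3 or to that of compound 4.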